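Solubility notes on the series: the step to compound 4

This account rests on a few compounds, and the source may have more. Where it says the series, first, only, none or still open, it means among the compounds named here.

Measured compounds in a physicochemical assay for solubility, read by HPLC, with a stated time of 30 min; on this read-out higher numbers stand for higher solubility and lower numbers for lower solubility:
compound 1 `O=C(Nc1nc(-c2cccc(F)c2)cs1)c1ccc([N+](=O)[O-])o1` gives 14.8 ug/mL
compound 2 `CCOc1cccc(-c2csc(NC(=O)c3ccc([N+](=O)[O-])o3)n2)c1` gives 0.34 ug/mL
compound 3 `O=C(Nc1nc(-c2cccc(OC3CCCC3)c2)cs1)c1ccc([N+](=O)[O-])o1` gives 0.027 ug/mL

Compound 3 stands lowest of the three numbers in this assay. Its nearest neighbour is compound 2, reached by a 13-fold lower number from compound 2 to compound 3 (1.10 log units; beyond the scatter); the furthest is compound 1, reached by a 550-fold lower number from compound 1 to compound 3 (2.74 log units; beyond the scatter). The remaining step, a 44-fold lower number from compound 1 to compound 2 (1.64 log units; beyond the scatter), also runs downward. Across these three compounds every replacement of fluoro by an alkoxy group, and every enlargement of that alkoxy group, lowered the number well beyond the scatter.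

Compound 4 `O=C(Nc1cccc(-c2csc(NC(=O)c3ccc([N+](=O)[O-])o3)n2)c1)c1ccccc1` is not yet measured. It differs from compound 3 by benzamido in place of cyclopentyloxy on an aromatic carbon. Within the data shown here, none of the measured steps introduces a benzamido group, so no step speaks directly to this change; the measured steps show only that groups larger than fluoro at this aromatic carbon gave markedly lower numbers, with no exception among compounds 1, 2 and 3. The entering group is larger again than the cyclopentyloxy it replaces, so a number near or somewhat below that of compound 3 is expected, with wide uncertainty. Compound 4 is estimated at 0.02 ug/mL, in the range 0.003 ug/mL to 0.2 ug/mL. This estimate corresponds to a 1.4-fold lower number from compound 3 to compound 4 (0.13 log units; within the scatter), and a reported limit rather than a number is a real possibility.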

Compound 4, solubility: 1.27 ug/mL
Estimate against measurement, compound 4: 64-fold (1.80 log units) below, and the stated range ends below it.
By their numbers in this assay, from the lowest: compound 3; then compound 2; then compound 4; then compound 1.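

In this assay, the size of the group at this aromatic carbon does not set the order by itself: benzamido, larger than the cyclopentyloxy it replaces, brings a clear rise (a 47-fold higher number from compound 3 to compound 4 (1.67 log units; beyond the scatter)), and compound 4 goes against the downward run seen from compound 1 through compound 2 to compound 3. The same group also stands modestly above ethoxy (a 3.7-fold higher number from compound 2 to compound 4 (0.57 log units; beyond the scatter)), while fluoro remains well ahead of it (a 12-fold lower number from compound 1 to compound 4 (1.07 log units; beyond the scatter)), so the entering amide recovers only part of the loss seen with the alkoxy groups. Benzamido brings a hydrogen-bond donor, a carbonyl and an aromatic ring to this place, but nothing available here bears on why the number rises, and no cause can be assigned.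

Which part of the benzamido group goes with the rise stays open, as this single amide does not separate the amide hydrogen, the carbonyl and the phenyl ring from one another. Also open is where a smaller acetamido group, a benzyloxy group or a plain amine at this aromatic carbon would fall in the order of these compounds.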